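A few compounds are considered here, and "the series" means these few. Any claim that something is new, unique, unknown or untested is made for them only; others in the source may bear on it.

Measured so far:
compound 1 `COc1ccc(-n2cc(-c3cc(O)cc(O)c3)nn2)c(OC)c1` — 10000 nM
compound 2 `COc1ccc(-n2cc(-c3cc(O)cc(O)c3)nn2)cc1O` — > 10000 nM
compound 3 `COc1cc(-n2cc(-c3ccc(N)cc3)nn2)cc(OC)c1OC` — > 10000 nM

In a functional assay on MDA-MB-231 cells (Homo sapiens) for cytotoxicity, read by MTT assay (on this read-out higher numbers stand for weaker inhibition and lower numbers for stronger inhibition), compound 3 gives only a limit of the assay, > 10000 nM, and no number. Compound 2 also gives only a limit, > 10000 nM. Compound 1 gives 10000 nM. Two of the three values thus sit at the limit of > 10000 nM in this assay, at which 2 of the 3 values shown sit, so compound 3 stands at the weak end of what has been seen, alongside compound 2. Compound 4 `COc1cc(-n2cc(-c3cc(O)cc(O)c3)nn2)cc(OC)c1OC` has not been measured; it differs from compound 3 by 3,5-dihydroxyphenyl in place of 4-aminophenyl on an aromatic carbon. Going by the values given here, no measured pair differs in exactly this way, so the size of this step is not known from the data. In this assay a step of no more than the usual scatter, in no clear direction, is expected. Compound 4 is estimated at 10000 nM, in the range 3000 nM to 30000 nM, which would mean a number no higher from compound 3 to compound 4 (the limit leaves the size open).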

Compound 4, half-maximal inhibitory concentration: > 10000 nM
Compound 4: no number, only a limit; the forecaster's own chance of this, stated with the estimate: 60%; the middle value lies on the limit itself.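

Going by these compounds alone, compound 3 and compound 4 both give only a limit of the assay, not a number, so no step between them can be read. The compounds shown leave open how 4-aminophenyl and 3,5-dihydroxyphenyl truly compare, because most values rest at one point: the limit of > 10000 nM in this assay, at which 3 of the 4 values shown sit.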